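Removing the Hydroxy Group from Compound 2

A few compounds are considered here, and "the series" means these few. Any claim that something is new, unique, unknown or untested is made for them only; others in the source may bear on it.

Measured compounds:
compound 1 `CN(C)CCn1nc(CN(C)C)n(-c2ccc(Cl)cc2C(=O)c2ccccc2)c1=O` gives 18 mg/kg
compound 2 `Cc1nnc(CN2CCCC2)n1-c1ccc(Cl)cc1C(O)c1ccccc1` gives 14 mg/kg
compound 3 `Cc1nnc(CN)n1-c1ccc(Cl)cc1C(O)c1ccccc1` gives 4 mg/kg

All three were tested in a functional assay on the whole organism (strain CF-1) for inhibition, with Mus musculus as the target; a lower number here means that less compound is needed, a higher number that more compound is needed for the effect. Compound 2 stands second highest of the three numbers; compound 1 lies within the scatter of it, while compound 3 lies clearly below it, as the step of a 3.5-fold lower number from compound 2 to compound 3 (0.54 log units; beyond the scatter) shows. Compound 4 `Cc1nnc(CN2CCCC2)n1-c1ccc(Cl)cc1Cc1ccccc1` differs from compound 2 at one place only: hydrogen in place of hydroxy on a saturated chain carbon bound to two aromatic carbons. Within the data shown here, no measured pair makes this change on its own, so the step from compound 2 to compound 3, which concerns a different group, does not bear on it, and compound 1 differs from compound 2 in more than one place. With nothing to go on, the expected outcome is no step beyond the scatter, no change at the digits printed from compound 2 to compound 4 (within the scatter). Compound 4 is therefore estimated at 14 mg/kg, within 6 mg/kg to 35 mg/kg.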

Compound 4, dose for half-maximal effect: > 100 mg/kg
Compound 4 ended at the assay's limit (the forecaster's own chance of this, stated with the estimate: 5%); middle value at least 7.1-fold (0.85 log units) away from the limit.
By their numbers in this assay, from the lowest: compound 3; then compounds 2 and 1 (each within the scatter of the next). At a limit, above all of these: compound 4.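

In this assay, replacing hydroxy by hydrogen on the saturated chain carbon bound to two aromatic carbons brings an at least 7.1-fold higher number from compound 2 to compound 4 (0.85 log units; beyond the scatter). Compound 4 gives > 100 mg/kg, which is a limit of the assay, so the step has a known minimum but no known full size. Among these compounds, the earlier step concerned a different group, so this is the first sign that the outcome in this assay depends on the hydroxy at this carbon.

On these data alone, it remains open what a methoxy group or an amine would give on this carbon. As far as these compounds go, it is also open whether the same change would act alike on compound 3, which carries amino in place of pyrrolidin-1-yl.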